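A few compounds are considered here, and "the series" means these few. Any claim that something is new, unique, unknown or untested is made for them only; others in the source may bear on it.

The measured compounds:
Compound 1, `CCOC(COC(N)=O)C1=C(N2CC2)C(=O)C(C)=C(N2CC2)C1=O`, gives 5.53 in a functional assay on L1210 cells (Mus musculus), with a stated time of 1 days; on this read-out lower numbers stand for lower potency and higher numbers for higher potency (the scale is a negative logarithm).
Compound 2, `CC1=C(N2CC2)C(=O)C(C(C)C)=C(N2CC2)C1=O`, gives 4.96.
Compound 3, `CC1=C(N2CC2)C(=O)C(C(C)COC(N)=O)=C(N2CC2)C1=O`, gives 5.93.

Compound 3 stands highest of the three in this assay. Compound 1 is nearest: a number 0.40 log units higher from compound 1 to compound 3 (beyond the scatter). Compound 2 is furthest: a number 0.97 log units higher from compound 2 to compound 3 (beyond the scatter). Both steps lie beyond the scatter, so compound 3 is the most potent of the measured set.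

Compound 4, `CCC(COC(N)=O)C1=C(N2CC2)C(=O)C(C)=C(N2CC2)C1=O`, has not yet been measured. Its difference from compound 3 is methyl in place of hydrogen on a saturated chain carbon, two bonds along the chain from a double-bonded ring carbon. For the measured compounds named here, none of the measured steps makes this same change. The step of a number 0.40 log units higher from compound 1 to compound 3 (beyond the scatter) also concerns the saturated chain, but it swaps ethoxy for methyl rather than adding a methyl to a chain carbon. The step of a number 0.97 log units higher from compound 2 to compound 3 (beyond the scatter) concerns the carbamoyloxy group, which compound 3 and compound 4 share. Neither gives a clear pointer for one extra methyl, so the estimated change is small and of no settled direction: a number 0.03 log units lower from compound 3 to compound 4 (within the scatter). Compound 4 is therefore expected to give about 5.9, with a likely range from 5.4 to 6.4.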

Compound 4, logarithm of the reciprocal of the active concentration, log(1/C): 6.03
Estimate against measurement, compound 4: 0.13 log units below; the measured number falls inside the stated range.
By their numbers in this assay, from the lowest: compound 2; then compound 1; then compounds 3 and 4 (each within the scatter of the next).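

Methyl in place of hydrogen on a saturated chain carbon, two bonds along the chain from a double-bonded ring carbon, gives a number 0.10 log units higher from compound 3 to compound 4 (within the scatter) in this assay and so cannot be told apart from no change at this place. Ethyl in place of ethoxy gives a number 0.50 log units higher from compound 1 to compound 4 (beyond the scatter) and methyl in place of ethoxy gives a number 0.40 log units higher from compound 1 to compound 3 (beyond the scatter) so both carbon groups read higher than ethoxy, and this position accepts methyl or ethyl without a loss beyond the scatter. Nothing shown gives a cause for these numbers.

The compounds shown leave open how a longer chain such as propyl would read at this place. They also leave open whether an amine or a hydroxyl there would fall with ethoxy or stand with methyl and ethyl.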